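The compounds below may be only part of what the source reports. "The series", "measured", "known", "first", "only" and "open" are said of these compounds alone.

Of the compounds shown here, two have been measured in a functional assay on SF-268 cells (Homo sapiens) for antiproliferative activity, read by sulforhodamine B assay, with a stated time of 72 h; on this read-out lower numbers stand for stronger inhibition and higher numbers for weaker inhibition. Compound 1 `NC(=S)NNc1nncc2ccccc12` gives 17 nM. Among the measured compounds shown here, compound 2 `Cc1cc(NS(=O)(=O)c2ccc(Nc3nncc4ccccc34)cc2)no1` gives 24 nM, which stands as the higher of the two numbers measured so far, yet the gap to compound 1 lies within the scatter. Compound 3 `O=S(=O)(Nc1ccccn1)c1ccc(Nc2nncc3ccccc23)cc1` differs from compound 2 in one place: pyridin-2-yl in place of 5-methyl-1,2-oxazol-3-yl on a sulfonamide nitrogen. For the measured compounds named here, no measured pair shows this change, so there is no step to lean on, and both measured compounds sit in a narrow band. Compound 3 is estimated at 30 nM, with a range of 10 nM to 90 nM. This corresponds to an expected step of a 1.3-fold higher number from compound 2 to compound 3 (0.10 log units; within the scatter), not beyond the scatter.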

Compound 3, half-maximal inhibitory concentration: 25 nM
Compound 3: the middle estimate sits 1.2-fold (0.08 log units) above what was measured; measured number inside the range.
By their numbers in this assay, from the lowest: compounds 1, 2 and 3 (each within the scatter of the next).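

In this assay, pyridin-2-yl in place of 5-methyl-1,2-oxazol-3-yl on a sulfonamide nitrogen gives a 1.0-fold higher number from compound 2 to compound 3 (0.02 log units; within the scatter). At this position, for this single pair, a six-membered aromatic ring with one hetero atom reads the same as a five-membered aromatic ring with two. No supporting data accompany this result, so it stands as a bare observation. The compounds shown leave open whether a methyl, a longer alkyl chain or a carboxylic acid-bearing chain on that sulfonamide nitrogen would read the same.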